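A Pyridine Carboxylic Acid Replaces the Benzimidazole

The source may report more compounds than this note shows. Statements on the series, on what has been measured and on what is new or still open speak of the compounds shown alone.

Of the compounds shown here, two have been measured in an assay on isolated protein for activation of cGMP-dependent protein kinase 1 (Homo sapiens), read by ADP-Glo, with stated times of 30 min and 2 h, in the presence of a further agent that is not named here; on this read-out lower numbers stand for an effect already at smaller amounts and higher numbers for an effect only at larger amounts of compound. Compound 1 `COC(=O)c1ccc(CN2CCC[C@H](O[C@H](CO)c3cc(Cl)cc(Cl)c3)[C@@H]2c2ccccc2)c(C)c1` gives 900 nM in this assay, and compound 2 `OC[C@@H](O[C@H]1CCCN(Cc2nc3ccccc3[nH]2)[C@H]1c1ccccc1)c1cc(Cl)cc(Cl)c1` gives 4700 nM. Going by the values given here, compound 2 therefore stands at the higher of the two numbers, with compound 1 as its only neighbour, and the one step recorded is a 5.2-fold higher number from compound 1 to compound 2 (0.72 log units; beyond the scatter), a change on a saturated chain carbon bound to an amine nitrogen in a ring.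

Compound 3 `Cc1nc(C(=O)O)ccc1CN1CCC[C@H](O[C@H](CO)c2cc(Cl)cc(Cl)c2)[C@@H]1c1ccccc1` differs from compound 2 at the same place: a group of 10 heavy atoms (7 carbon, 1 nitrogen, 2 oxygen; one six-membered aromatic ring with 1 hetero atom) in place of a group of 9 heavy atoms (7 carbon, 2 nitrogen; one five-membered aromatic ring with 2 hetero atoms, one six-membered aromatic ring of carbon only), on a saturated chain carbon bound to an amine nitrogen in a ring. Among the compounds with values here, only the step from compound 1 to compound 2 bears on this exchange, and it is of modest size. Compound 3 carries an aromatic ring with a carbonyl-bearing substituent and a methyl group, which brings it nearer to compound 1 than to compound 2. The step from compound 2 to compound 3 is therefore expected to run toward lower numbers, as a 3.1-fold lower number from compound 2 to compound 3 (0.50 log units; beyond the scatter), though not necessarily all the way back to compound 1. For compound 3 the estimate in this assay is 1500 nM, with a range from 500 nM to 4500 nM.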

Compound 3, half-maximal effective concentration: 370 nM
Estimate against measurement, compound 3: 4.1-fold (0.61 log units) above; measured number below the stated range.
By their numbers in this assay, from the lowest: compound 3; then compound 1; then compound 2.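

In this assay, going by these compounds alone, the exchange of the 1H-benzimidazol-2-yl group for the carboxylic acid-bearing six-membered aromatic ring with 1 hetero atom gives a 13-fold lower number from compound 2 to compound 3 (1.10 log units; beyond the scatter), so this place on the saturated chain carbon bound to an amine nitrogen in a ring spans a wider range than the single earlier step showed. The new group does more than return to the level of compound 1, as a 2.4-fold lower number from compound 1 to compound 3 (0.39 log units; beyond the scatter) places compound 3 at the lowest number of the three, beyond the scatter from both other compounds. Nothing measured here accounts for why this group gives the lowest number.

Compound 1 and compound 3 differ in the ring, in the carboxylic acid against the methyl ester, and in how the groups are arranged on the ring, all in a single exchange, so the compounds shown cannot divide the step among these features. A carboxylic acid on the benzene ring of compound 1, or a methyl ester or primary amide on the ring of compound 3, would be needed to tell how much of the step belongs to the ring and how much to the carboxylic acid.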